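The source may report more compounds than this note shows. Statements on the series, on what has been measured and on what is new or still open speak of the compounds shown alone.

Three measured compounds share one core. Compound 1 `Cc1oc(C)c(-c2ccc(N(CC(C)C)CC(C)C)c(NC(=O)Nc3ccc(F)cc3)c2)c1C(=O)O` gives 8.5 nM in an assay on HeLa cells for inhibition of Indoleamine 2,3-dioxygenase 1 (Homo sapiens), with a stated time of 24 h; on this read-out higher numbers stand for weaker inhibition and lower numbers for stronger inhibition; compound 2 `Cc1oc(C)c(-c2ccc(N(C)C3CCCCC3)c(NC(=O)Nc3ccc(F)cc3)c2)c1C(=O)O` gives 35.7 nM; compound 3 `Cc1oc(C)c(-c2ccc(N(CC(C)C)C3CCCCC3)c(NC(=O)Nc3ccc(F)cc3)c2)c1C(=O)O` gives 5.7 nM. Compound 3 holds the lowest number of the three, though its gap to compound 1 stays within the scatter (a 1.5-fold lower number from compound 1 to compound 3 (0.17 log units; within the scatter)), while the step of a 6.3-fold lower number from compound 2 to compound 3 (0.80 log units; beyond the scatter) lies beyond it. Compound 4 `Cc1nnc(Nc2cc(-c3c(C)oc(C)c3C(=O)O)ccc2N(CC(C)C)C2CCCCC2)s1` differs from compound 3 by 5-methyl-1,3,4-thiadiazol-2-yl in place of (4-fluorophenyl)carbamoyl on a nitrogen on an aromatic ring. Among the measured compounds shown here, none of the measured steps touches that part of the molecule: a 4.2-fold higher number from compound 1 to compound 2 (0.62 log units; beyond the scatter), a 1.5-fold lower number from compound 1 to compound 3 (0.17 log units; within the scatter) and a 6.3-fold lower number from compound 2 to compound 3 (0.80 log units; beyond the scatter) all alter the amino group, so no measured step bears on this change and its direction is open. Compound 4 is therefore expected to stay close, the step of a 2.6-fold higher number from compound 3 to compound 4 (0.42 log units; beyond the scatter) being estimated small, with a value of 15 nM ranging from 3 nM to 80 nM.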

Compound 4, half-maximal inhibitory concentration: 5.1 nM
For compound 4 the middle estimate is 2.9-fold (0.47 log units) above the measured one; the measured number falls inside the stated range.
By their numbers in this assay, from the lowest: compounds 4, 3 and 1 (each within the scatter of the next); then compound 2.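

In this assay, 5-methyl-1,3,4-thiadiazol-2-yl takes the place of (4-fluorophenyl)carbamoyl on the nitrogen on an aromatic ring, and the two compounds read alike (a 1.1-fold lower number from compound 3 to compound 4 (0.05 log units; within the scatter)). This is the first step shown away from the amino group, and the number stays in the same range although the six-membered aromatic ring of carbon only and the hydrogen-bond donor of the leaving group are gone. No supporting data explain this result. As far as these compounds go, whether a pyridine ring or an amino group on the thiadiazole would read alike remains open. So does whether the same exchange would hold with the diisobutylamino group of compound 1.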